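Working notes: bromophenyl placement on compound 1

A few compounds are considered here, and "the series" means these few. Any claim that something is new, unique, unknown or untested is made for them only; others in the source may bear on it.

For the measured compounds named here, compound 1 `S=C(N/N=C/c1ccc2ccccc2n1)Nc1ccc(Br)cc1` is the only member of the set with a numerical result: in a functional assay on SGC-7901 cells (Homo sapiens) for antiproliferative activity, read by sulforhodamine B assay, with a stated time of 72 h (a lower number here means a stronger inhibitor, a higher number a weaker inhibitor), compound 1 gives 69400 nM. Compound 2 `Cc1ccc(NC(=O)N/N=C/c2ccc3ccccc3n2)cc1` reaches only a limit of the assay, > 100000 nM. Compound 3 `Cc1csc2sc(/C=N/NC(N)=S)c(C)c12` likewise returns only a limit, > 100000 nM. Going by the values given here, two of the three results therefore sit at the limit of > 100000 nM in this assay, at which 2 of the 3 values shown sit, and no measured step between compounds is available to calibrate a change. Compound 4 `S=C(N/N=C/c1ccc2ccccc2n1)Nc1cccc(Br)c1` differs from compound 1 in one place: 3-bromophenyl in place of 4-bromophenyl on an amide-type nitrogen. With the same atoms joined differently and nothing measured to lean on, the expected change from compound 1 to compound 4 is none beyond the usual scatter, a 1.0-fold lower number from compound 1 to compound 4 (0.00 log units; within the scatter). Compound 4 is accordingly estimated at 69000 nM, within 25000 nM to 150000 nM, with a fair chance that this assay reports only a limit.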

Compound 4, half-maximal inhibitory concentration: 78600 nM
For compound 4 the middle estimate is 1.1-fold (0.06 log units) below the measured one; the range from low to high includes it.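

In this assay, for the compounds shown here, 3-bromophenyl in place of 4-bromophenyl on the amide-type nitrogen gives a 1.1-fold higher number from compound 1 to compound 4 (0.05 log units; within the scatter), the first measured step. At this position, the two bromophenyl placements cannot be told apart in this assay. The other compounds add no step: the limit of > 100000 nM in this assay, at which 2 of the 4 values shown sit.

On these data alone, whether an amine or a carboxylic acid in place of the bromine would move the value beyond the scatter remains open. As far as these compounds go, the role of the thiocarbonyl also remains open, since compound 2 differs from compound 1 in more than one place.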